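The compounds below may be only part of what the source reports. "The series", "measured", "known", "first", "only" and "open" are said of these compounds alone.

Working notes on the series. The only full measurement so far belongs to compound 1 `Fc1ccccc1Cn1cc(CSC(=S)N2CCNCC2)nn1`, which in a functional assay on MCF7 cells (Homo sapiens) for inhibition, read by MTT assay, with a stated time of 72 h (on this read-out higher numbers stand for weaker inhibition and lower numbers for stronger inhibition), gives 33200 nM; on the numbers shown it stands alone, and that number marks weak inhibition. Compound 2 `COc1cc(Cn2cc(CSC(=S)N3CCNCC3)nn2)cc(OC)c1OC` has as its entry in this assay only "not determined" (no result reported), so it offers no comparison. Compound 3 `Cc1ccc(Cn2cc(CSC(=S)N3CCNCC3)nn2)cc1` is the next entry awaiting a value in this assay. Its difference from compound 1 is 4-methylphenyl in place of 2-fluorophenyl on a saturated chain carbon bound to an aromatic nitrogen. Within the data shown here, no pair of measured compounds yields a step to calibrate this change, so there is no basis for predicting movement beyond the usual scatter in this assay. The step from compound 1 to compound 3 is expected to be a 1.1-fold higher number from compound 1 to compound 3 (0.02 log units; within the scatter), essentially none beyond the scatter. Compound 3 is therefore expected to give about 35000 nM in this assay, with a plausible range from 12000 nM to 100000 nM, the width reflecting the single anchor.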

Compound 3, half-maximal inhibitory concentration: 53200 nM
The estimate for compound 3 lay 1.5-fold (0.18 log units) below the measured number; the measured number falls inside the stated range.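

In this assay, among these compounds, the replacement of 2-fluorophenyl by 4-methylphenyl on a saturated chain carbon bound to an aromatic nitrogen gives a 1.6-fold higher number from compound 1 to compound 3 (0.20 log units; within the scatter) and so provides the first calibrated step at this position. Compound 1 and compound 3 cannot be separated on these numbers, which shows that this particular exchange, with fluorine leaving and a methyl group entering, does not register as a real change in this cell read-out. No supporting measurement bears on this result.

Among the compounds shown here, the single step changes both the substituent and its printed location on the aromatic ring, so the contribution of each cannot be told apart. As far as these compounds go, whether plain phenyl, a carboxylic acid or an amine on that ring, or a longer chain in place of the saturated chain carbon would move the number beyond the scatter remains open.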